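The compounds below may be only part of what the source reports. "The series", "measured", "known", "first", "only" and "open" are said of these compounds alone.

Of the compounds shown here, three have so far been tested in a functional assay for activation of Alpha-1A adrenergic receptor (Homo sapiens); on this read-out higher numbers stand for an effect only at larger amounts of compound and lower numbers for an effect already at smaller amounts. Compound 1 `COc1ccc(S(C)(=O)=O)c(NCC2=NCCN2)c1` gives 12.6 nM, compound 2 `CS(=O)(=O)c1ccccc1NCc1c[nH]cn1` gives 126 nM, and compound 3 `c1ccc(-c2ccccc2OCc2c[nH]cn2)cc1` gives 15.9 nM. Compound 3 therefore stands second highest of the three; its number and that of compound 1 lie within the usual scatter of each other, whereas compound 2 sits clearly higher, beyond the scatter. Compound 4 `c1ccc(-c2ccno2)c(OCc2c[nH]cn2)c1` has not yet been measured. It differs from compound 3 in a single place: 1,2-oxazol-5-yl in place of phenyl on an aromatic carbon. Among the measured compounds shown here, no measured pair shows this exchange, so its effect cannot be read from the numbers at hand. A modest rise in the number is expected, a step of a 2.5-fold higher number from compound 3 to compound 4 (0.40 log units; beyond the scatter) that need not exceed the scatter. Compound 4 is thus estimated at 40 nM, with a range from 10 nM to 200 nM.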

Compound 4, half-maximal effective concentration: 158 nM
Beside the measured number, compound 4's estimate is 4.0-fold (0.60 log units) below it; the range from low to high includes it.
By their numbers in this assay, from the lowest: compounds 1 and 3 (each within the scatter of the next); then compounds 2 and 4 (each within the scatter of the next).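

Among the compounds shown here, putting 1,2-oxazol-5-yl in place of phenyl gives a 9.9-fold higher number from compound 3 to compound 4 (1.00 log units; beyond the scatter) and, as the only pair here differing in one place, provides the first direct reading of a change at this position. The position, ortho to a group of 7 heavy atoms, therefore does not treat these two aromatic rings alike: the five-membered ring with 2 hetero atoms needs clearly more compound for the same effect. No measurement shown explains this step.

Going by these compounds, how a small methyl group, an amine or a pyridine ring would fare at this position remains open. It is also unknown whether the ring nitrogen, the ring oxygen or the smaller ring size drives the change.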